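The source may hold more compounds than are shown below. What is called first, only, known or untested is meant among the compounds shown, and "the series" means these compounds.

Compound 1 `Nc1c(-c2nc3ccccc3[nH]2)cc(-c2ccccc2)n1-c1ccccn1`: 8000 nM
Compound 2 `Nc1c(-c2nc3ccccc3[nH]2)cc(-c2ccccc2)n1-c1cccc(Br)c1`: 13500 nM

In a functional assay on A549 cells (Homo sapiens) for cytotoxicity, read by resazurin assay, with a stated time of 72 h (a higher number here means a weaker inhibitor, a lower number a stronger inhibitor), compound 2 gives 13500 nM, a value within the scatter of compound 1 at 8000 nM. Compound 3 `Nc1c(-c2nc3ccccc3[nH]2)cc(-c2ccccc2)n1Cc1nc2ccccc2[nH]1` has not yet been measured. It differs from compound 2 on an aromatic nitrogen: (1H-benzimidazol-2-yl)methyl in place of 3-bromophenyl on an aromatic nitrogen. For the measured compounds named here, only one measured step concerns that same place, a 1.7-fold higher number from compound 1 to compound 2 (0.23 log units; within the scatter), and it lies within the scatter. The two groups compared in that step are single aromatic rings, while the entering (1H-benzimidazol-2-yl)methyl is a different kind of group, so the step offers only limited guidance. No change beyond the scatter is therefore expected in this assay, and no direction can be favoured with confidence. The estimate amounts to an expected 1.4-fold lower number from compound 2 to compound 3 (0.13 log units; within the scatter). Compound 3 is estimated at 10000 nM, with an expected range from 3000 nM to 30000 nM.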

Compound 3, half-maximal inhibitory concentration: 5100 nM
Compound 3: the middle estimate sits 2.0-fold (0.29 log units) above what was measured, and the stated range covers the measured number.
By their numbers in this assay, from the lowest: compounds 3, 1 and 2 (each within the scatter of the next, the first and the last beyond it).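

In this assay, for the compounds shown here, the first step at this position to pass the scatter comes from a group that is not a single aromatic ring directly on the nitrogen: (1H-benzimidazol-2-yl)methyl in place of 3-bromophenyl gives a 2.6-fold lower number from compound 2 to compound 3 (0.42 log units; beyond the scatter). Set against pyridin-2-yl, the same group gives a 1.6-fold lower number from compound 1 to compound 3 (0.20 log units; within the scatter), so the outcome of this change depends on which group it replaces, and the separation appears only against 3-bromophenyl. Nothing available bears on the reason for this result.

The compounds shown leave open whether the (1H-benzimidazol-2-yl) part or its methyl link matters more, which a plain benzyl group on the aromatic nitrogen could test. They also leave open how a longer chain ending in an amine would read out at this position.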